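The compounds below may be only part of what the source reports. "The series", "measured", "known", "first", "only" and "open" are said of these compounds alone.

Measured so far:
- Compound 1 `NC1=NC2(CCSCC2)N(OCCCOc2cccc(Cl)c2)C(N)=N1` gives 1 nM
- Compound 2 `NC1=NC2(CCOCC2)N(OCCCOc2cccc(Cl)c2)C(N)=N1` gives 120 nM

Both compounds were tested in a functional assay on HCT-116 cells (Homo sapiens) for antiproliferative activity, read by MTT assay, with a stated time of 72 h; a lower number here means a stronger inhibitor, a higher number a weaker inhibitor. Among the measured compounds shown here, compound 2 has the higher of the two numbers, and therefore the weaker activity; compound 1, its only neighbour here, sits far lower, and that gap is well beyond the ordinary scatter of this assay. For the measured compounds named here, the two differ in the shared core, where a sulfur atom of compound 1 is replaced by an oxygen in compound 2; no step has been worked out for that pair, so only the two values themselves can be compared.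

The step followed here leads from compound 2 to compound 3 `NC1=NC2(CCOCC2)N(OCCCOc2ccc(Cl)c(Cl)c2)C(N)=N1`. The change is chloro in place of hydrogen on an aromatic carbon. Cut one bond further out, it reads as 3-chlorophenyl becoming 3,4-dichlorophenyl, with the new chloro placed ortho to the existing chloro group and para to a large group.

Nothing measured here tells how such a change plays out, so the expectation rests on compound 2 alone. A modest move toward a lower number is expected, the step from compound 2 to compound 3 being a 2.0-fold lower number from compound 2 to compound 3 (0.30 log units; within the scatter), possibly no larger than the scatter. Compound 3 is therefore estimated at 60 nM, within a range from 15 nM to 300 nM.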

Compound 3, half-maximal inhibitory concentration: 90 nM
Compound 3: middle estimate off by 1.5-fold (0.18 log units), on the low side; the range from low to high includes it.
By their numbers in this assay, from the lowest: compound 1; then compounds 3 and 2 (each within the scatter of the next).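

In this assay, going from 3-chlorophenyl to 3,4-dichlorophenyl gives a 1.3-fold lower number from compound 2 to compound 3 (0.12 log units; within the scatter), a step within the usual scatter of repeated measurements, so the two compounds cannot be told apart in this test. Among the compounds shown here, this is the first look at this position on the aromatic ring, ortho to a chloro group and para to a large group, and it shows that, with the oxygen-containing core of compound 2, a chloro can take the place of hydrogen here with no change that the assay can resolve. Nothing measured here accounts for why the step is so small.

On these data alone, it remains open whether this position would respond differently to a group other than chloro, such as a methoxy group, an amine or a carboxylic acid, since a single added chlorine atom says little about larger groups or groups of another kind. As far as these compounds go, it is also open whether the same added chloro would leave the number just as unmoved on the sulfur-containing core of compound 1, where the starting value is far lower.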